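The source may report more compounds than this note shows. Statements on the series, on what has been measured and on what is new or still open speak of the compounds shown alone.

Measured in a functional assay on MCF7 cells (Homo sapiens) for inhibition, read by MTT assay, with a stated time of 72 h, tested at 50 uM; on this read-out lower numbers stand for less inhibition of growth and higher numbers for more inhibition of growth at the one concentration tested:
Compound 1 `C=CCc1ccc(OCc2cn(-c3cccc([N+](=O)[O-])c3)nn2)c(O)c1`: 56.5%
Compound 2 `C=CCc1ccc(OCc2cn(-c3ccc(OC)cc3)nn2)c(O)c1`: 57.2%

Only these two compounds have been measured so far. Compound 2 stands level with compound 1, since their two values lie within the usual scatter of repeated measurements. The next compound, compound 3 `C=CCc1ccc(OCc2cn(-c3ccc(Br)cc3)nn2)c(O)c1`, changes one place in compound 2: bromo in place of methoxy on an aromatic carbon. In words, bromo takes the place of methoxy on an aromatic carbon, turning 4-methoxyphenyl into 4-bromophenyl.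

Going by the values given here, no measured pair yet shows what a single change of this kind does in this assay. Among the compounds with values here, the only guide is that compound 1 at 56.5% and compound 2 at 57.2% lie within the scatter of each other. No step beyond the scatter is therefore expected, and the estimated step is a number 0.8 percentage points higher from compound 2 to compound 3 (within the scatter). The expected value for compound 3 is 58%, within an estimated range of 45% to 71%.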

Compound 3, percent growth inhibition at one concentration: 29.1%
Compound 3: middle estimate off by 28.9 percentage points, on the high side, outside the stated range (below it).
By their numbers in this assay, from the lowest: compound 3; then compounds 1 and 2 (each within the scatter of the next).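

Going by these compounds alone, this is the first single change that can be read in this assay, and bromo in place of methoxy gives a number 28.1 percentage points lower from compound 2 to compound 3 (beyond the scatter) at this position. The group on this aromatic carbon, para to a large group, is therefore not a free choice: replacing methoxy with bromo, which also replaces two heavy atoms with one and removes one hydrogen-bond acceptor, is enough to reduce growth inhibition at the one concentration tested. Nothing available here explains why this swap has such an effect.

Still open, as far as these compounds go, is whether the drop follows from the arrival of bromo or the departure of methoxy. An amine, a carboxylic acid or a longer chain such as butoxy on the same carbon would help separate these two readings, and would show how widely this position responds to change.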